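Working notes: the step from compound 3 to compound 4

This account rests on a few compounds, and the source may have more. Where it says the series, first, only, none or still open, it means among the compounds named here.

Measured in an ADME assay on HepG2 cells (Homo sapiens) for cytotoxicity, in the presence of a further agent that is not named here; on this read-out higher numbers stand for weaker inhibition and lower numbers for stronger inhibition:
- compound 1 `CN(Cc1ccccc1)C(=O)c1nc(Cc2ccccc2C(F)(F)F)n(C)c(=O)c1O`, limit > 100000 nM
- compound 2 `Cn1c(Cc2ccccc2C(F)(F)F)nc(C(=O)NCC2CCCCC2)c(O)c1=O`, limit > 100000 nM
- compound 3 `CC(NC(=O)c1nc(Cc2ccccc2C(F)(F)F)n(C)c(=O)c1O)c1ccccc1`, limit > 100000 nM

In this assay compound 3 stands at > 100000 nM, which is a limit and not a number. The whole set reads the same way: the limit of > 100000 nM in this assay, at which 3 of the 3 values shown sit.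

The change to compound 4 `Cn1c(Cc2ccccc2C(F)(F)F)nc(C(=O)CCc2ccccc2)c(O)c1=O` is phenethyl in place of (1-phenylethyl)amino on a carbonyl carbon.

Among the measured compounds shown here, the steps that bear on it are a step that the two limits leave unreadable from compound 1 to compound 3 and a step that the two limits leave unreadable from compound 2 to compound 3, and a step that the two limits leave unreadable from compound 1 to compound 2 gives no size either. No step beyond the scatter is therefore expected in this assay, in either direction. The expected step is a number no higher from compound 3 to compound 4 (the limit leaves the size open).

For compound 4 the estimate is 100000 nM, with an expected range from 40000 nM to 200000 nM.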

Compound 4, half-maximal inhibitory concentration: > 100000 nM
Compound 4: no number, only a limit; the forecaster's own chance of this, stated with the estimate: 85%; the middle value sits exactly at the limit.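

In this assay compound 4 gives > 100000 nM, a limit and not a number. Among the compounds shown here, no step among compound 1, compound 2, compound 3 and compound 4 can be read. The compounds shown leave open whether any change on this carbonyl carbon shifts the read-out: the limit of > 100000 nM in this assay, at which 4 of the 4 values shown sit.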